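A few compounds are considered here, and "the series" means these few. Any claim that something is new, unique, unknown or untested is made for them only; others in the source may bear on it.

Of the compounds shown here, three built on one shared core have so far been measured in an ADME assay on microsomes from liver (Homo sapiens) for metabolic stability; a lower number here means that the compound disappears faster, a higher number that the compound lasts longer. Compound 1 `CC(C)[C@H](C[C@H]1CCNC1=O)c1ccc(-c2ccc3cccc(F)c3c2)[nH]c1=O` gives 0.257 h in this assay. Compound 2 `CCC(CC)(c1nnc[nH]1)c1ccc(-c2ccc3cccc(F)c3c2)[nH]c1=O` gives 1.19 h. Compound 3 `CC(C)C(c1nnc[nH]1)c1ccc(-c2ccc3cccc(F)c3c2)[nH]c1=O` gives 0.905 h, which is the second highest of the three numbers: the gap to compound 2 lies within the usual scatter of repeated measurements, while the gap to compound 1, whose number is lower, lies beyond it.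

Compound 4 `Cc1c[nH]c(C(c2ccc(-c3ccc4cccc(F)c4c3)[nH]c2=O)C(C)C)n1` has not yet been measured in this assay. It differs from compound 3 in one place: 4-methyl-1H-imidazol-2-yl in place of 4H-1,2,4-triazol-3-yl on a saturated chain carbon bound to an aromatic carbon and a saturated chain carbon. Going by the values given here, no pair of measured compounds shows this kind of exchange, so its size can only be guessed. A modest downward step, roughly at the edge of the scatter, is expected, and the estimated step is a 1.5-fold lower number from compound 3 to compound 4 (0.18 log units; within the scatter). Compound 4 is therefore expected to give about 0.6 h in this assay, most likely between 0.3 h and 1.2 h.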

Compound 4, half-life: 0.09 h
Compound 4: middle estimate off by 6.7-fold (0.82 log units), on the high side; measured number outside the range, below it.
By their numbers in this assay, from the lowest: compound 4; then compound 1; then compounds 3 and 2 (each within the scatter of the next).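

Going by these compounds alone, until this result, no measured pair showed what a change to the group on this saturated chain carbon does on its own. In this assay, placing 4-methyl-1H-imidazol-2-yl where 4H-1,2,4-triazol-3-yl stood gives a 10-fold lower number from compound 3 to compound 4 (1.00 log units; beyond the scatter), so one exchange at this position is enough to shift the half-life well beyond the scatter. No accompanying data bear on why the step is this large.

The exchange alters the ring and adds a methyl group at once, so the step cannot be divided between the two changes. Going by these compounds, a plain imidazole ring without the methyl, or a triazole carrying a methyl group, would separate them, and it remains open whether the same exchange would have a similar effect with the two ethyl groups of compound 2 on that carbon.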